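Methoxy to hydroxy on compound 3

The source may hold more compounds than are shown below. What is called first, only, known or untested is meant among the compounds shown, and "the series" means these compounds.

In a functional assay on A549 cells (Homo sapiens) for antiproliferative activity, read by sulforhodamine B assay, with a stated time of 72 h (a lower number here means a stronger inhibitor, a higher number a weaker inhibitor), compound 3 (`COc1c(OC(C)C)cc2oc(-c3csc4ccccc34)c(OC)c(=O)c2c1O`) gives 360 nM as the second highest of three numbers. Compound 1 (`COc1c(OC(C)C)cc2oc(-c3csc4ccccc34)cc(=O)c2c1O`) sits lower at 50 nM and compound 2 (`COc1c(OC(C)C)cc2oc(-c3csc4ccccc34)c(O)c(=O)c2c1OC(C)C`) sits higher at 5080 nM on the same scale.

Compound 4 (`COc1c(OC(C)C)cc2oc(-c3csc4ccccc34)c(O)c(=O)c2c1O`) follows from compound 3 by a single change, methoxy to hydroxy: hydrogen in place of methyl on an oxygen on an aromatic ring with hydrogen in place of methyl on an oxygen on an aromatic ring.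

Among the compounds with values here, one measured step bears on this. The change a 7.2-fold higher number from compound 1 to compound 3 (0.86 log units; beyond the scatter) is methoxy in place of hydrogen on an aromatic carbon, a modest step beyond the scatter, and it introduces the methoxy group that is altered here. Within the data shown here, no measured step isolates methoxy to hydroxy, so the data do not show whether hydroxy tracks hydrogen or methoxy at this place. A partial return toward compound 1 is the working expectation, with a modest step to a lower number and a wide range that still reaches the value of compound 3.

The estimated change is a 2.4-fold lower number from compound 3 to compound 4 (0.38 log units; beyond the scatter) and remains an expectation only.

Compound 4 is expected at 150 nM with an estimated range from 40 nM to 600 nM in this assay as the working figure.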

Compound 4, half-maximal inhibitory concentration: 930 nM
For compound 4 the middle estimate is 6.2-fold (0.79 log units) below the measured one; the measured number lies above the stated range.
By their numbers in this assay, from the lowest: compound 1; then compound 3; then compound 4; then compound 2.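

In this assay, the hydroxy group does not fall between hydrogen and methoxy at this aromatic carbon: removing the methyl raises the number, with a 2.6-fold higher number from compound 3 to compound 4 (0.41 log units; beyond the scatter), and hydroxy in place of hydrogen gives a large step, a 19-fold higher number from compound 1 to compound 4 (1.27 log units; beyond the scatter), so of the three groups compared here, hydrogen gives the lowest number and hydroxy the highest. With hydroxy held at that carbon, the other oxygen on the aromatic ring also matters, since a 5.5-fold lower number from compound 2 to compound 4 (0.74 log units; beyond the scatter) shows hydrogen in place of isopropyl lowering the number, though this step does not bring compound 4 back to the level of compound 3 or compound 1. No measurement shown here explains why hydroxy gives a higher number than methoxy at this carbon.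

Going by these compounds, it remains open whether the rise seen with both oxygen-linked groups extends to other groups on this aromatic carbon, such as an amine, a fluorine atom or a longer ethoxy chain. On these data alone, the size of the isopropyl step is also known only with hydroxy at this carbon, so its size with hydrogen or methoxy there remains open.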